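The source may hold more compounds than are shown below. What is called first, only, known or untested is meant among the compounds shown, and "the series" means these compounds.

In a physicochemical assay for lipophilicity, read by HPLC, in phosphate buffer, measured as octanol-water partition, with a stated time of 1 h, at pH 7.4 (a higher number here means a more lipophilic compound, a lower number a more polar compound), compound 1 (`Cc1cc(C#N)cnc1C(=O)Nc1ccc(F)c([C@]2(C)C=C(CF)OC(N)=N2)c1`) gives 2.5 and compound 2 (`C[C@@]1(c2cc(NC(=O)c3coc(C(F)F)n3)ccc2F)C=C(CF)OC(N)=N1`) gives 2.6 on the same scale, so the two measured compounds sit level within the scatter and compound 2 holds no real lead. For the measured compounds named here, compound 3 (`C[C@@]1(c2cc(NC(=O)c3ncc(OCF)nc3N)ccc2F)C=C(CF)OC(N)=N1`) has no measurement yet. Its difference from compound 2 is 3-amino-5-(fluoromethoxy)pyrazin-2-yl in place of 2-(difluoromethyl)-1,3-oxazol-4-yl on a carbonyl carbon with the rest of the structure unchanged, that is, 3-amino-5-(fluoromethoxy)pyrazin-2-yl in place of 2-(difluoromethyl)-1,3-oxazol-4-yl on a carbonyl carbon.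

Going by the values given here, only one measured step bears on this, an exchange on the same kind of carbonyl carbon, with 2-(difluoromethyl)-1,3-oxazol-4-yl in place of 5-cyano-3-methylpyridin-2-yl. Among the compounds with values here, the entering group has no measured precedent, so the support is thin. Within the data shown here, with a number 0.10 log units higher from compound 1 to compound 2 (within the scatter) as the only guide, no step beyond the scatter is expected in this assay for this exchange. The estimated move is a number 0.20 log units lower from compound 2 to compound 3 (within the scatter) and it stays within that scatter. Compound 3 is expected at 2.4 with an estimated range from 1.9 to 2.9 on this scale.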

Compound 3, distribution coefficient: 3.1
Compound 3: the middle estimate sits 0.70 log units below what was measured; the whole stated range lies below it.
By their numbers in this assay, from the lowest: compounds 1 and 2 (each within the scatter of the next); then compound 3.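

At the carbonyl carbon bearing the amide-type nitrogen, the exchange between compound 1 and compound 2 gave no separation in this assay, whereas 3-amino-5-(fluoromethoxy)pyrazin-2-yl gives a clear one, with a number 0.50 log units higher from compound 2 to compound 3 (beyond the scatter) and a number 0.60 log units higher from compound 1 to compound 3 (beyond the scatter). This shows that the read-out can respond to the group at this position, and that the response is not tied to simple donor and acceptor counts: the entering group has 1 hydrogen-bond donor and 4 hydrogen-bond acceptors against 0 and 2 for 2-(difluoromethyl)-1,3-oxazol-4-yl, yet compound 3 stands higher than compound 2. No supporting data accompany this result to account for the rise.

The exchange changes the aromatic ring, the amino group and the fluoromethoxy group together, so the compounds shown leave open which of these parts carries the step. A methoxy group in place of the fluoromethoxy group, or a hydrogen in place of the amino group, on the same ring would separate those contributions in this assay.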